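A few compounds are considered here, and "the series" means these few. Any claim that something is new, unique, unknown or untested is made for them only; others in the source may bear on it.

Measured so far in an ADME assay on HepG2 cells (Homo sapiens) for inhibition, with a stated time of 48 h; on this read-out higher numbers stand for an effect only at larger amounts of compound and lower numbers for an effect already at smaller amounts:
- Compound 1 `Brc1ccc(Nc2nc(NCc3ccco3)c3ccccc3n2)cc1` gives 19000 nM
- Compound 2 `Fc1ccc(Nc2nc(NCc3ccccc3)c3ccncc3n2)cc1` gives 17800 nM
- Compound 3 `CN1CCN(CCNc2nc(Nc3ccc(F)c(Cl)c3)nc3cccnc23)CC1` gives 8900 nM

Compound 3 at 8900 nM lies within the scatter of compound 2 at 17800 nM. Compound 1 sits at 19000 nM. Only compound 1 stands apart from compound 3, narrowly beyond the scatter and on the higher side.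

Compound 4 `CN1CCN(CCNc2nc(Nc3ccc(Cl)c(F)c3)nc3cccnc23)CC1` has yet to be measured. It has the same atoms as compound 3, joined differently, and 4-chloro-3-fluorophenyl in place of 3-chloro-4-fluorophenyl on a nitrogen on an aromatic ring is the whole change: 4-chloro-3-fluorophenyl in place of 3-chloro-4-fluorophenyl on a nitrogen on an aromatic ring. Among the measured compounds shown here, no two measured compounds differ in one place only, so the data give no direct size for such a change. With compound 3 at 8900 nM as the closest measured structure, no step beyond the scatter is expected in this assay here. The estimated step of a 1.0-fold higher number from compound 3 to compound 4 (0.00 log units; within the scatter) is expected to stay within the scatter. For compound 4 the estimated value is 9000 nM with an expected range from 5000 nM to 16000 nM in this read-out.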

Compound 4, half-maximal effective concentration: 12300 nM
Compound 4: the middle estimate sits 1.4-fold (0.14 log units) below what was measured; the measured number falls inside the stated range.
By their numbers in this assay, from the lowest: compounds 3, 4, 2 and 1 (each within the scatter of the next, the first and the last beyond it).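

Among the compounds shown here, measured in this assay the exchange of 3-chloro-4-fluorophenyl for 4-chloro-3-fluorophenyl on a nitrogen on an aromatic ring gives a 1.4-fold higher number from compound 3 to compound 4 (0.14 log units; within the scatter) and provides the first step in this set that changes one place only. For the compounds shown here, at this position, then, moving from one of these two arrangements of the same halogens to the other does not take the read-out beyond the usual scatter, a result the earlier compounds could not show. Nothing available here explains this outcome.

The compounds shown leave open whether another group on this nitrogen, such as an unsubstituted phenyl or a 4-methoxyphenyl, would shift the number beyond the scatter. They also leave open what would happen if the side chain shared by compound 3 and compound 4 gave way to a morpholine or a carboxylic acid.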